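Furan-2-yl for 4-methoxyphenyl on the nitrooxy amide core

The source may hold more compounds than are shown below. What is called first, only, known or untested is meant among the compounds shown, and "the series" means these compounds.

Working notes on a small set of enone amides. Compound 1 `COc1ccc(/C=C/C(=O)c2ccc(NC(=O)C(C)Br)cc2)cc1` carries a 4-methoxyphenyl on the double-bonded chain and a bromo on the saturated amide chain. In a functional assay on the whole organism (strain albino) for inhibition, with Rattus norvegicus as the target, read by paw edema, with stated times of 30 min and 1 h, at a dose of 100 mg/kg by the oral route (a lower number here means less inhibition, a higher number more inhibition at the dose given (going by the name of the read-out)), compound 1 gives 39%. Compound 2 `CC(Br)C(=O)Nc1ccc(C(=O)/C=C/c2ccco2)cc1` differs from compound 1 by furan-2-yl in place of 4-methoxyphenyl on a double-bonded chain carbon bound to a double-bonded chain carbon; in this assay compound 2 gives 30%, and the step is a number 9 percentage points lower from compound 1 to compound 2 (within the scatter). Compound 3 `COc1ccc(/C=C/C(=O)c2ccc(NC(=O)C(C)O[N+](=O)[O-])cc2)cc1` differs from compound 1 by nitrooxy in place of bromo on a saturated chain carbon bound to a carbonyl carbon and a saturated chain carbon, which is the whole difference between the two cores. In this assay compound 3 gives 43%, the step being a number 4 percentage points higher from compound 1 to compound 3 (within the scatter).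

Compound 4 `CC(O[N+](=O)[O-])C(=O)Nc1ccc(C(=O)/C=C/c2ccco2)cc1` has not been measured. It differs from compound 3 by furan-2-yl in place of 4-methoxyphenyl on a double-bonded chain carbon bound to a double-bonded chain carbon. The place is worded the same as for the change from compound 1 to compound 2, so this is the same change, now made on the core that carries nitrooxy rather than bromo. Among the compounds here that change has one measured example, a number 9 percentage points lower from compound 1 to compound 2 (within the scatter), and the nitrooxy core itself is set by a number 4 percentage points higher from compound 1 to compound 3 (within the scatter).

For compound 4 the expected value in this assay is 34%, with a range from 22% to 46%. Among the compounds with values here, the expected step is a number 9 percentage points lower from compound 3 to compound 4 (within the scatter), estimated to follow the earlier example because a number 9 percentage points lower from compound 1 to compound 2 (within the scatter) is the only measured instance of this change and nothing here suggests the nitrooxy core should respond differently.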

Compound 4, a percentage reported as inhibition, in the whole organism at one dose (the size of the read-out at that dose, not a potency): 41%
Estimate against measurement, compound 4: 7 percentage points below; the measured number falls inside the stated range.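

In this assay, the step for furan-2-yl in place of 4-methoxyphenyl on the core carrying nitrooxy is a number 2 percentage points lower from compound 3 to compound 4 (within the scatter), and the two measured examples of this change do not separate: the same change on two cores in this assay, a number 9 percentage points lower (within the scatter) from compound 1 to compound 2 and a number 2 percentage points lower (within the scatter) from compound 3 to compound 4, 7 percentage points apart, within the scatter of two such steps. The reverse pairing, nitrooxy in place of bromo, gives a number 11 percentage points higher from compound 2 to compound 4 (beyond the scatter) on the core carrying furan-2-yl, so this step lies beyond the scatter while its counterpart on the core of compound 1 does not, yet the two steps themselves cannot be told apart: the same change on two cores in this assay, a number 4 percentage points higher (within the scatter) from compound 1 to compound 3 and a number 11 percentage points higher (beyond the scatter) from compound 2 to compound 4, 7 percentage points apart, within the scatter of two such steps. Both changes therefore carry from one core to the other within the resolution of this read-out, but with a single pair on each core this does not show that the steps are equal, nor that the effect of nitrooxy depends on the group on the double-bonded chain.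

The compounds shown leave open whether the pattern holds for other groups at the same places, such as an amine or a hydroxyl in place of bromo and nitrooxy, or an unsubstituted phenyl or thiophen-2-yl in place of furan-2-yl. They also leave open how these compounds compare at other doses, since inhibition at a single dose is not a potency.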